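Moving a methoxy group in a growth-inhibitor series

This account rests on a few compounds, and the source may have more. Where it says the series, first, only, none or still open, it means among the compounds named here.

Compound 1 `COc1cc2oc(-c3cccc(NC(=O)c4ccc(Cl)cc4)c3)cc(=O)c2c(OC)c1OC`: 21300 nM
Compound 2 `COc1cc2oc(-c3cccc(NC(=O)c4ccc(C#N)cc4)c3)cc(=O)c2c(OC)c1OC`: 10200 nM
Compound 3 `COc1ccc(C(=O)Nc2cccc(-c3cc(=O)c4c(OC)c(OC)c(OC)cc4o3)c2)cc1`: 22200 nM

These three compounds share a core and differ in a single group. All were tested in a functional assay on HepG2 cells (Homo sapiens) for inhibition, read by MTT assay; a lower number here means a stronger inhibitor of growth, a higher number a weaker inhibitor of growth. Exchanging that group gave a 2.1-fold lower number from compound 1 to compound 2 (0.32 log units; beyond the scatter), a 1.0-fold higher number from compound 1 to compound 3 (0.02 log units; within the scatter) and a 2.2-fold higher number from compound 2 to compound 3 (0.34 log units; beyond the scatter). Compound 3, at 22200 nM, therefore sits level with compound 1, and both stand at a higher number than compound 2.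

The next compound, compound 4 `COc1cccc(C(=O)Nc2cccc(-c3cc(=O)c4c(OC)c(OC)c(OC)cc4o3)c2)c1`, has not yet been measured. It differs from compound 3 as follows: 3-methoxyphenyl in place of 4-methoxyphenyl on a carbonyl carbon. In short, 3-methoxyphenyl stands in place of 4-methoxyphenyl on a carbonyl carbon.

Within the data shown here, no measured step shows a change of this kind, because each one exchanges one group for a different group, while here the atoms stay the same and are joined differently. Among the measured compounds shown here, these steps are still the only guide. Even the largest of them, a 2.2-fold higher number from compound 2 to compound 3 (0.34 log units; beyond the scatter), is modest, so a large shift seems unlikely, and the expectation starts from compound 3 at 22200 nM. The step expected is a 1.1-fold lower number from compound 3 to compound 4 (0.05 log units; within the scatter), which would be none beyond the scatter. For compound 4 the estimated value is 20000 nM, with an expected range from 9000 nM to 45000 nM.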

Compound 4, concentration for 50% growth inhibition: 7060 nM
Estimate against measurement, compound 4: 2.8-fold (0.45 log units) above, outside the stated range (below it).
By their numbers in this assay, from the lowest: compounds 4 and 2 (each within the scatter of the next); then compounds 1 and 3 (each within the scatter of the next).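

Moving the methoxy group while keeping the same atoms gave a 3.1-fold lower number from compound 3 to compound 4 (0.50 log units; beyond the scatter) in this assay, a change on the ring attached to the carbonyl carbon that is at least comparable with the exchanges of one group for another among the earlier compounds, the biggest of which was a 2.2-fold higher number from compound 2 to compound 3 (0.34 log units; beyond the scatter). So, among these compounds, where the methoxy group sits on this ring matters, and not only which group is present. The 3-methoxyphenyl compound also shows a 3.0-fold lower number from compound 1 to compound 4 (0.48 log units; beyond the scatter), yet with a 1.4-fold lower number from compound 2 to compound 4 (0.16 log units; within the scatter) it cannot be told apart from the 4-cyanophenyl compound, so moving the methoxy group brings the number level with the best earlier result rather than clearly past it.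

Nothing given here accounts for the effect of moving the methoxy group, so the reason for the step remains unknown. From the compounds shown here alone, it also remains open whether the gain belongs to the methoxy group alone, or whether another group on the same ring, such as an amine or a carboxylic acid, would give a similar number.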